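Fluoroalkoxy chain length and stereochemistry in a quinuclidine-triazole series

The source may hold more compounds than are shown below. What is called first, only, known or untested is meant among the compounds shown, and "the series" means these compounds.

Of the compounds shown here, three have been measured in an assay on HEK293 cells for displacement of a labelled ligand from Neuronal acetylcholine receptor; alpha4/beta2 (Homo sapiens), read by scintillation counting, with a stated time of 120 min; on this read-out higher numbers stand for weaker inhibition and lower numbers for stronger inhibition. Compound 1 `FCCOc1cccc(-c2cn([C@H]3CN4CCC3CC4)nn2)c1` gives 7050 nM. Compound 2 `FCCCOc1cccc(-c2cn([C@H]3CN4CCC3CC4)nn2)c1` gives 9010 nM. Compound 3 `FCCCOc1cccc(-c2cn([C@@H]3CN4CCC3CC4)nn2)c1` gives 1980 nM, the lowest of the three numbers, with compound 1 nearest and compound 2 furthest.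

The step from compound 2 to compound 1 is a 1.3-fold lower number from compound 2 to compound 1 (0.11 log units; within the scatter); the change is fluoro in place of fluoromethyl on a saturated chain carbon, two bonds along the chain from an oxygen on an aromatic ring. Among the measured compounds shown here, the step from compound 2 to compound 3 is a 4.6-fold lower number from compound 2 to compound 3 (0.66 log units; beyond the scatter); the difference is the two compounds have the same atoms and bonds; at least one stereo element is drawn with a configuration in one of them and without one in the other: 1 of 3 stereo elements differ; a stereocentre at a saturated ring carbon is drawn R in compound 2 and S in compound 3, and the only evidence bearing on it is the fact that one of compounds 2 and 3 is drawn with a defined configuration and the other without, at the place where they differ.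

Compound 4 `FCCOc1cccc(-c2cn([C@@H]3CN4CCC3CC4)nn2)c1` has not yet been measured in this assay. From compound 3 it differs by fluoro in place of fluoromethyl on a saturated chain carbon, two bonds along the chain from an oxygen on an aromatic ring. This is the same change as that from compound 2 to compound 1, both made at a place described in identical words; it occurs twice among the compounds shown. The two cores on which it is made differ by the two compounds have the same atoms and bonds; at least one stereo element is drawn with a configuration in one of them and without one in the other: 1 of 3 stereo elements differ; a stereocentre at a saturated ring carbon is drawn R in compound 2 and S in compound 3.

For the measured compounds named here, the step from compound 3 to compound 4 in this assay is expected to be a 1.2-fold lower number from compound 3 to compound 4 (0.09 log units; within the scatter), a shift of about the same size as the one seen from compound 2 to compound 1, resting on a 1.3-fold lower number from compound 2 to compound 1 (0.11 log units; within the scatter) as the single precedent for this change. Compound 4 is therefore estimated at 1600 nM, with a plausible range from 700 nM to 3600 nM.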

Compound 4, inhibition constant: 1260 nM
Estimate against measurement, compound 4: 1.3-fold (0.10 log units) above; measured number inside the range.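

In this assay, going from 3-fluoropropoxy to 2-fluoroethoxy on the core of compound 3 gives a 1.6-fold lower number from compound 3 to compound 4 (0.20 log units; within the scatter), and the change reads alike on the two cores: the same change on two cores in this assay, a 1.3-fold lower number (0.11 log units; within the scatter) from compound 2 to compound 1 and a 1.6-fold lower number (0.20 log units; within the scatter) from compound 3 to compound 4, 1.2-fold (0.09 log units) apart, within the scatter of two such steps

The gap between the two configurations also persists with the 2-fluoroethoxy chain, at a 5.6-fold lower number from compound 1 to compound 4 (0.75 log units; beyond the scatter), so within these four compounds the configuration at the saturated ring carbon marks a step beyond the scatter, while the chain change does not. Among the compounds shown here, this shows only that a change with no step beyond the scatter on one core also has none on the other; it does not show that a real shift carries over, and the two cores differ at a single stereocentre, so nothing follows for cores that differ in any other way.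

The compounds shown leave open how a longer chain such as 4-fluorobutoxy, a plain ethoxy group without fluorine or a trifluoromethoxy group would read on either core. They also leave open whether the gap between the two configurations would hold with such groups in place of the fluoroalkoxy chains.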